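A few compounds are considered here, and "the series" means these few. Any claim that something is new, unique, unknown or untested is made for them only; others in the source may bear on it.

Measured so far:
- compound 1, `COc1cc(N2CCCNCC2)cnc1Cl`, gives 116%
- compound 2, `COc1cncc(N2CCCNCCC2)c1`, gives 89%
- compound 3, `CCSc1ccc(N2CCCNCC2)cn1`, gives 53%

These three compounds were tested in an assay on HEK293 cells with Neuronal acetylcholine receptor; alpha4/beta2 (Homo sapiens) as the target, read by FLIPR and calcium flux; a lower number here means a smaller maximal response, a higher number a larger maximal response. Compound 3 stands lowest of the three numbers: its value is beyond the scatter below that of compound 2 and still further below that of compound 1. Compound 4, `COc1ccc(N2CCCNCC2)cn1`, has not yet been measured. It differs from compound 3 in one place: methoxy in place of ethylsulfanyl on an aromatic carbon. Going by the values given here, no step between two measured compounds isolates this change, so its effect is not known. Because compound 1 shows 116% and compound 2 shows 89%, both carrying a methoxy, a rise beyond the scatter is expected, an estimated step of a number 32 percentage points higher from compound 3 to compound 4 (beyond the scatter). Compound 4 is expected to give about 85%, between 55% and 115%.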

Compound 4, largest response reached (reported as efficacy), in percent of the reference or control that the assay uses: 88%
Compound 4: middle estimate off by 3 percentage points, on the low side; measured number inside the range.
By their numbers in this assay, from the lowest: compound 3; then compounds 4 and 2 (each within the scatter of the next); then compound 1.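

In this assay, placing methoxy instead of ethylsulfanyl on this aromatic carbon next to the ring nitrogen gives a number 35 percentage points higher from compound 3 to compound 4 (beyond the scatter), a large step. Going by these compounds alone, this is the first direct reading of a change at this place, and it shows that the maximal response depends on the group held there while the rest of the core stays the same. Nothing measured here gives a reason for this step.

The step swaps sulfur for oxygen and shortens the chain at once, and the compounds shown cannot separate the two. Ethoxy or methylsulfanyl at this place would tell them apart, and how an amine would fare there also stays open.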